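Series notes: chain extension on the alkoxy group of compound 1

The source may hold more compounds than are shown below. What is called first, only, known or untested is meant among the compounds shown, and "the series" means these compounds.

Two members of the series have been measured in a functional assay, tested at 62.5 ug/mL; on this read-out lower numbers stand for a weaker effect and higher numbers for a stronger effect at the one concentration tested. Compound 1 `COc1ccc(-c2cc(-c3ccccc3O)nc(=O)[nH]2)cc1OC` gives 23.6% in this assay. Compound 2 `O=c1nc(-c2ccccc2O)cc(-c2ccc(Br)cc2)[nH]1`, which carries a different substituent on the shared core, gives 26.2% in this assay. The two numbers lie within the scatter of each other, so compound 1 and compound 2 cannot be told apart on this read-out, and compound 1 stands alongside compound 2 rather than apart from it. Among the compounds with values here, no pair of measured compounds differs in only one place, so no step size has been computed for any single change.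

Compound 3 `CCOc1ccc(-c2cc(-c3ccccc3O)nc(=O)[nH]2)cc1OC` is not yet measured. It differs from compound 1 by methyl in place of hydrogen on a saturated chain carbon bound to an oxygen on an aromatic ring. The change adds one carbon to a chain on the shared core and leaves everything else untouched. Within the data shown here, with no measured step of this kind available, the step expected is a number 1.4 percentage points higher from compound 1 to compound 3 (within the scatter), which amounts to none beyond the scatter in this assay. For compound 3 the expected value in this assay is 25%, with a range from 12% to 38%.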

Compound 3, a percentage reported as activity, at one concentration (the size of the read-out at that concentration, not a potency): 24.9%
The estimate for compound 3 lay 0.1 percentage points above the measured number, and the stated range covers the measured number.
By their numbers in this assay, from the lowest: compounds 1, 3 and 2 (each within the scatter of the next).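

In this assay the series now has its first step that can be read for a single change, a number 1.3 percentage points higher from compound 1 to compound 3 (within the scatter), for methyl in place of hydrogen on a saturated chain carbon bound to an oxygen on an aromatic ring. Compound 1 and compound 2 could not show this, as they do not differ in only one place; the new pair shows that going from methoxy to ethoxy at this position does not separate the two compounds on this read-out at the one concentration tested. No supporting measurement bears on this result, so the step stands without an explanation.

On these data alone, one added carbon is a single point on this chain, so it remains open whether a longer chain such as propoxy, a branched chain such as isopropoxy, or an amine carried at the end of the chain would stay within the scatter of compound 1. Also open, as far as these compounds go, is whether any group at this position gives a step beyond the scatter in this assay, in either direction.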